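This account rests on a few compounds, and the source may have more. Where it says the series, first, only, none or still open, it means among the compounds named here.

Measured so far:
compound 1 `CC1=CC[C@H]2[C@@H]1CC=C(C)[C@@H](CC[C@H]1[C@]3(C)CC[C@H](OC(=O)c4ccccc4)C(C)(C)O[C@H]3CC[C@@]1(C)O)C2(C)C`: 18400 nM
compound 2 `CC1=CC[C@H]2[C@H](CC[C@]2(C)O)C(C)(C)[C@@H]1CC[C@H]1[C@]2(C)CC[C@H](OCc3ccccc3)C(C)(C)O[C@H]2CC[C@@]1(C)O`: 29100 nM

In a functional assay on MDA-MB-231 cells (Homo sapiens) for antiproliferative activity, read by MTT assay, with a stated time of 72 h (on this read-out higher numbers stand for weaker inhibition and lower numbers for stronger inhibition), compound 1 gives 18400 nM and compound 2 gives 29100 nM. Compound 2 holds the larger of the two numbers, but its gap to compound 1 lies within the scatter, so the two read as alike. Within the data shown here, no pair of measured compounds differing in one place is available, so no measured step anchors the series.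

Compound 3 `CC1=CC[C@H]2[C@H](CC[C@]2(C)O)C(C)(C)[C@@H]1CC[C@H]1[C@]2(C)CC[C@H](OC(=O)c3ccc([N+](=O)[O-])o3)C(C)(C)O[C@H]2CC[C@@]1(C)O` is to be measured in this assay. Relative to compound 2 the change is (5-nitrofuran-2-yl)carbonyl in place of benzyl on an oxygen on a saturated carbon. Among the measured compounds shown here, nothing measured bears directly on this change; the only guide is that both measured numbers sit close together at weak inhibition. The step is therefore expected to be small, a 1.3-fold lower number from compound 2 to compound 3 (0.12 log units; within the scatter), with no direction beyond the scatter. Compound 3 is expected at 22000 nM, within a range of 8000 nM to 60000 nM.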

Compound 3, half-maximal inhibitory concentration: 11100 nM
Compound 3: the middle estimate sits 2.0-fold (0.30 log units) above what was measured; the range from low to high includes it.
By their numbers in this assay, from the lowest: compounds 3, 1 and 2 (each within the scatter of the next, the first and the last beyond it).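

In this assay, among these compounds, the oxygen on a saturated carbon in the shared core responds to what it carries: (5-nitrofuran-2-yl)carbonyl in place of benzyl gives a 2.6-fold lower number from compound 2 to compound 3 (0.42 log units; beyond the scatter) and is the first step to stand beyond the scatter. The step is modest, and compound 3 at 11100 nM still sits at weak inhibition, so this position gives a measurable but limited response to this change. No supporting data bear on the origin of this step.

The change alters the linking carbonyl and the ring together, so the compounds shown leave open which of the two carries the step. A furan-2-ylcarbonyl group without the nitro group, or a (5-nitrofuran-2-yl)methyl group, would separate these two parts at this position.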